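Adding methoxy to the phenyl of compound 2

A few compounds are considered here, and "the series" means these few. Any claim that something is new, unique, unknown or untested is made for them only; others in the source may bear on it.

In a functional assay on the whole organism (arterial blood) with Rattus norvegicus as the target (a higher number here means that more compound is needed for the effect, a lower number that less compound is needed), compound 1 `Cc1nc2cnccc2n1CC1CCN(C(=O)CCc2ccccc2)CC1` gives > 5 mg/kg as a limit and not a number. Among the measured compounds shown here, compound 2 `Cc1nc2cnccc2n1CC1CCN(C(=O)CN(C)c2ccccc2)CC1` gives 0.31 mg/kg as the only actual number so far. For the measured compounds named here, the single measured step of an at least 16-fold lower number from compound 1 to compound 2 (1.20 log units; beyond the scatter) is large, with methyl(phenyl)amino in place of benzyl on a saturated chain carbon bound to a carbonyl carbon. Compound 3 `COc1ccccc1N(C)CC(=O)N1CCC(Cn2c(C)nc3cnccc32)CC1` keeps that arm and carries methoxy in place of hydrogen on an aromatic carbon as methoxy in place of hydrogen on an aromatic carbon. Going by the values given here, no measured step tests this change, so no step beyond the scatter is expected in this assay and neither direction is favoured. For compound 3 the estimated value is 0.3 mg/kg with an expected range from 0.08 mg/kg to 1.2 mg/kg in this assay. This estimate means an expected 1.0-fold lower number from compound 2 to compound 3 (0.01 log units; within the scatter) and nothing larger.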

Compound 3, dose for 50% inhibition: 0.063 mg/kg
The estimate for compound 3 lay 4.8-fold (0.68 log units) above the measured number; the whole stated range lies above it.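

In this assay, among the compounds shown here, methoxy on the phenyl, giving 2-methoxyphenyl, brings a 4.9-fold lower number from compound 2 to compound 3 (0.69 log units; beyond the scatter), so this aromatic carbon responds to substitution, which the earlier compounds could not show. Across the whole arm, the change now reaches an at least 79-fold lower number from compound 1 to compound 3 (1.89 log units; beyond the scatter). That step rests on compound 1, whose entry is a limit and not a number: the limit of > 5 mg/kg in this assay, at which 1 of the 3 values shown sits.

The compounds shown leave open whether fluoro or hydroxy on this carbon would give a similar step, and whether methoxy on another carbon of the ring would do so.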